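Longer Alkyl Chain on the Amide of Compound 1

The compounds below may be only part of what the source reports. "The series", "measured", "known", "first", "only" and "open" are said of these compounds alone.

For the measured compounds named here, compound 1 `C#CCNC(=O)/C=C/c1c(/C=C/c2ccc(OC)cc2)cc(OC)cc1OC` shows the highest of the three numbers measured so far in a functional assay on A549 cells (Homo sapiens) for inhibition, read by MTT assay, with a stated time of 48 h (on this read-out lower numbers stand for stronger inhibition and higher numbers for weaker inhibition), giving 6930 nM. Compound 2 `CCC(C)NC(=O)/C=C/c1c(/C=C/c2ccc(OC)cc2)cc(OC)cc1OC` gives 3950 nM, and compound 3 `COc1ccc(/C=C/c2cc(OC)cc(OC)c2/C=C/C(=O)N2CCC(c3ccccc3)CC2)cc1` gives 6690 nM; the step of a 1.8-fold lower number from compound 1 to compound 2 (0.24 log units; within the scatter) and the step of a 1.0-fold lower number from compound 1 to compound 3 (0.02 log units; within the scatter) both stay within the scatter, so the three compounds cannot be ranked. Compound 4 `CCCCCCNC(=O)/C=C/c1c(/C=C/c2ccc(OC)cc2)cc(OC)cc1OC` differs from compound 1 in one place: pentyl in place of ethynyl on a saturated chain carbon bound to an amide-type nitrogen. Going by the values given here, the closest precedent is the change of propargyl to sec-butyl, where a 1.8-fold lower number from compound 1 to compound 2 (0.24 log units; within the scatter) was seen; replacing propargyl by a saturated chain shifted little there, and the hexyl chain of compound 4 is expected to behave alike. For compound 4 an expected value of 5000 nM, within 2000 nM to 12000 nM, corresponds to a 1.4-fold lower number from compound 1 to compound 4 (0.14 log units; within the scatter), no step beyond the scatter.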

Compound 4, half-maximal inhibitory concentration: 6230 nM
Compound 4: the middle estimate sits 1.2-fold (0.10 log units) below what was measured, and the stated range covers the measured number.
By their numbers in this assay, from the lowest: compounds 2, 4, 3 and 1 (each within the scatter of the next).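

At this amide-type nitrogen, the straight hexyl chain adds a fourth group to the series in this assay, and it still gives no separable change (a 1.1-fold lower number from compound 1 to compound 4 (0.05 log units; within the scatter); a 1.6-fold higher number from compound 2 to compound 4 (0.20 log units; within the scatter); a 1.1-fold lower number from compound 3 to compound 4 (0.03 log units; within the scatter)). The triple bond can therefore leave and a pentyl group can replace the ethynyl without a step beyond the scatter. Nothing available explains why these numbers stay together.

Still open, on these data alone, is whether a longer chain, or a chain ending in an amine or a carboxylic acid, would move the number beyond the scatter.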